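A Sulfanyl Group Replaces the Benzylamino Group

The source may hold more compounds than are shown below. What is called first, only, known or untested is meant among the compounds shown, and "the series" means these compounds.

Of the compounds shown here, two on a shared core have been measured so far. Compound 1 `Nc1cc(N)c2nc(-c3ccccc3)c(NCc3ccc(F)cc3)nc2c1` gives 30900 nM in a functional assay on A498 cells (Homo sapiens) for inhibition, read by sulforhodamine B assay, with a stated time of 48 h (a higher number here means a weaker inhibitor of growth, a lower number a stronger inhibitor of growth), the only plain number shown. Compound 2 `COc1ccc(CNc2nc3cc(N)cc(N)c3nc2-c2ccccc2)cc1` gives in this assay only a limit of the assay, < 100000 nM. The step that the limit leaves unreadable from compound 1 to compound 2 is therefore unreadable, since the limit of < 100000 nM in this assay, at which 1 of the 2 values shown sits, hides its size. Compound 3 `Nc1cc(N)c2nc(-c3ccccc3)c(Sc3ccc(F)cc3)nc2c1` differs from compound 1 by (4-fluorophenyl)sulfanyl in place of (4-fluorobenzyl)amino on an aromatic carbon. Within the data shown here, no measured step touches this change, so nothing beyond the scatter is expected in either direction. Compound 3 is therefore estimated at 30000 nM, between 8000 nM and 100000 nM, an expected step of a 1.0-fold lower number from compound 1 to compound 3 (0.01 log units; within the scatter).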

Compound 3, concentration for total growth inhibition: < 100000 nM
Compound 3: only a limit was reported (the forecaster's own chance of this, stated with the estimate: 30%); the middle value lies beyond the limit too.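

Compound 3, like compound 2, is reported only as a limit, so no step from compound 1 to either can be read: the limit of < 100000 nM in this assay, at which 2 of the 3 values shown sit.

As far as these compounds go, whether the (4-fluorophenyl)sulfanyl group strengthens or weakens growth inhibition in this assay compared with the (4-fluorobenzyl)amino group stays open.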